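The source may report more compounds than this note shows. Statements on the series, on what has been measured and on what is new or still open speak of the compounds shown alone.

Measured so far:

- compound 1, `O=S(=O)(/C=C/c1ncccc1F)c1ccc(F)cc1`: 542 nM
- compound 2, `O=S(=O)(/C=C/c1ncccc1F)c1ccc(Cl)cc1`: 286 nM
- compound 3, `O=S(=O)(/C=C/c1cccnc1Cl)c1ccc(F)cc1`: 339 nM

The three compounds were tested in an assay on U2OS cells for activation of nuclear factor erythroid 2-related factor 2 (Homo sapiens), read by beta-arrestin recruitment, with a stated time of 6 h; on this read-out lower numbers stand for an effect already at smaller amounts and higher numbers for an effect only at larger amounts of compound. Compound 1 and compound 2 share one core and differ in a single spot: chloro in place of fluoro on an aromatic carbon. That change gave a 1.9-fold lower number from compound 1 to compound 2 (0.28 log units; within the scatter), so the two values cannot be told apart with confidence.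

Compound 3 carries a different core, and the difference between the two cores is not broken down here. In this assay compound 3 gives 339 nM, a number that sits within the scatter of both compound 1 and compound 2, so no order among the three can be claimed.

Compound 4, `O=S(=O)(/C=C/c1cccnc1Cl)c1ccc(Cl)cc1`, has not yet been measured. It relates to compound 3 exactly as compound 2 relates to compound 1: chloro in place of fluoro on an aromatic carbon. Since the spot of the change and the groups that leave and enter are the same in both pairs, this is the same change, now made on the other core.

Among the measured compounds shown here, only one earlier example of this change is available, and because that example, a 1.9-fold lower number from compound 1 to compound 2 (0.28 log units; within the scatter), stayed within the scatter, the step is expected to be small again: a 1.8-fold lower number from compound 3 to compound 4 (0.25 log units; within the scatter) is the estimated size. Compound 4 is therefore expected to give about 190 nM in this assay, with a likely range from 90 nM to 400 nM.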

Compound 4, half-maximal effective concentration: 305 nM
The estimate for compound 4 lay 1.6-fold (0.21 log units) below the measured number; low and high end bracket the measured number.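

On the core of compound 3, chloro in place of fluoro gave a 1.1-fold lower number from compound 3 to compound 4 (0.05 log units; within the scatter) in this assay, so this step, like the earlier one, is too small to be told apart from the usual scatter of repeated measurements. Set side by side, the two steps do not differ, and the change carries over from one core to the other only in a modest sense, namely that it stayed small on both: the same change on two cores in this assay, a 1.9-fold lower number (0.28 log units; within the scatter) from compound 1 to compound 2 and a 1.1-fold lower number (0.05 log units; within the scatter) from compound 3 to compound 4, 1.7-fold (0.23 log units) apart, within the scatter of two such steps. This does not show that chloro and fluoro really differ on either core, as neither step stands clear of the scatter, and two cores are a small sample from which to speak for a whole series.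

The compounds shown only exchange fluoro and chloro at this one place, which leaves open what a group of another kind would do there, such as an amine, a carboxylic acid or a longer chain. Also open, from the compounds shown here alone, is whether the exchange would stay as small on a core other than these two, and whether the same picture would hold in a read-out other than this assay.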